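Aryl change on the ring nitrogen: expected cytotoxicity

The source may hold more compounds than are shown below. What is called first, only, known or untested is meant among the compounds shown, and "the series" means these compounds.

Working notes on the series. Compound 1 `CCc1ccc(-n2nc(-c3ccc(C(F)(F)F)cc3O)nc2-c2ccccc2O)cc1` is the reference here; in a functional assay on PC-12 cells (Rattus norvegicus) for cytotoxicity, read by MTT assay, with stated times of 2 h and 24 h, tested at 10 uM (a lower number here means a weaker effect, a higher number a stronger effect of the compound at the concentration tested), compound 1 gives 107%, the highest of the three numbers in hand. Compound 2 `CC(C)(C)c1ccc(-n2nc(-c3ccc(C(F)(F)F)cc3O)nc2-c2ccccc2O)cc1` gives 81.1% in this assay, and compound 3 `Oc1cc(C(F)(F)F)ccc1-c1nc(-c2ccccc2O)n(-c2ccc(OC(F)(F)F)cc2)n1` gives 92.5%. The measured steps all sit on the same aromatic carbon of the group on the ring nitrogen: a number 25.9 percentage points lower from compound 1 to compound 2 (beyond the scatter), a number 14.5 percentage points lower from compound 1 to compound 3 (beyond the scatter), and a number 11.4 percentage points higher from compound 2 to compound 3 (beyond the scatter). Compound 4 `Oc1cc(C(F)(F)F)ccc1-c1nc(-c2ccccc2O)n(-c2cc(F)cc(F)c2)n1` differs from compound 1 by 3,5-difluorophenyl in place of 4-ethylphenyl on an aromatic nitrogen. The two steps starting from compound 1 bear on this change, as both also alter the group on the ring nitrogen, and both lowered the number modestly, the larger being a number 25.9 percentage points lower from compound 1 to compound 2 (beyond the scatter). Among the measured compounds shown here, no measured step exchanges the whole group, so the expectation rests on these two. A modest drop in this assay is therefore expected, a number 17 percentage points lower from compound 1 to compound 4 (beyond the scatter). For compound 4 the estimate in this assay is 90%, with a range from 70% to 110%.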

Compound 4, a percentage reported as activity, at one concentration (the size of the read-out at that concentration, not a potency): 106%
Estimate against measurement, compound 4: 16 percentage points below; the measured number falls inside the stated range.
By their numbers in this assay, from the lowest: compound 2; then compound 3; then compounds 4 and 1 (each within the scatter of the next).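

In this assay the exchange of the whole group on the aromatic nitrogen gives a number 1 percentage points lower from compound 1 to compound 4 (within the scatter) and so separates 3,5-difluorophenyl from 4-ethylphenyl by no more than the usual variation between repeats. The other two groups do stand apart from 3,5-difluorophenyl, with a number 13.5 percentage points higher from compound 3 to compound 4 (beyond the scatter) and a number 24.9 percentage points higher from compound 2 to compound 4 (beyond the scatter) in the same assay, so among these four compounds the lower numbers go with 4-(trifluoromethoxy)phenyl and 4-(tert-butyl)phenyl and do not follow every departure from 4-ethylphenyl. Nothing at hand accounts for this difference between the groups.

As far as these compounds go, whether an amine or a carboxylic acid on this phenyl ring would give a number like that of 3,5-difluorophenyl stays open. So does the outcome for a longer chain in place of the ethyl group of compound 1.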